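A few compounds are considered here, and "the series" means these few. Any claim that something is new, unique, unknown or untested is made for them only; others in the source may bear on it.

The measured compounds are:

compound 1, `CC(C(=O)N1CCN(c2ccc(Cl)cc2)CC1)N1C(=O)CCC1=O`, giving 100%;
compound 2, `CCC(C(=O)N1CCN(c2cccc(Cl)c2)CC1)N1C(=O)CCC1=O`, giving 50%;
compound 3, `CC(C(=O)N1CCN(c2cccc(Cl)c2)CC1)N1C(=O)CCC1=O`, giving 100%.

All three were tested in a functional assay on the whole organism (strain Swiss) with Mus musculus as the target, in the maximal electroshock model, with a stated time of 0.5 h, at a dose of 300 mg/kg by the intraperitoneal route; a lower number here means a weaker effect, a higher number a stronger effect of the compound at the dose given. Compound 3 and compound 1 differ only in the group on the amine nitrogen of the six-membered non-aromatic ring, (4-chlorophenyl in place of 3-chlorophenyl on an amine nitrogen in a ring), and the step was no change at the digits printed from compound 3 to compound 1 (within the scatter). Compound 2 and compound 3 differ in their cores, (methyl in place of hydrogen on a saturated chain carbon, two bonds along the chain from an amide-type nitrogen in a ring and a carbonyl carbon), and here the step was a number 50 percentage points higher from compound 2 to compound 3 (beyond the scatter), so compound 2 stands lowest of the three, beyond the scatter from both compound 1 and compound 3.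

Compound 4, `CCC(C(=O)N1CCN(c2ccc(Cl)cc2)CC1)N1C(=O)CCC1=O`, has not yet been tested in this assay. It differs from compound 2 by 4-chlorophenyl in place of 3-chlorophenyl on an amine nitrogen in a ring, which is the same change as the one from compound 3 to compound 1, with the same place around it word for word; it is made twice among these four compounds. On compound 3 that change left the read-out unchanged, no change at the digits printed from compound 3 to compound 1 (within the scatter), though compound 3 already stood at the top of the scale, so whether the change could have raised a lower starting point is not known. Because compound 2 gives 50%, compound 4 is expected to stay near it, and the step from compound 2 to compound 4 is estimated at no change at the digits printed from compound 2 to compound 4 (within the scatter). Compound 4 is estimated to give 50% in this assay, with a likely span from 25% to 85%.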

Compound 4, a percentage reported as activity, at one dose (the size of the read-out at that dose, not a potency): 0%
The estimate for compound 4 lay 50 percentage points above the measured number; the whole stated range lies above it.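

On the core of compound 2, the change to 4-chlorophenyl in this assay gave a number 50 percentage points lower from compound 2 to compound 4 (beyond the scatter), so the result of this change on the core of compound 3 did not carry over: the same change on two cores in this assay, no change at the digits printed (within the scatter) from compound 3 to compound 1 and a number 50 percentage points lower (beyond the scatter) from compound 2 to compound 4, 50 percentage points apart, beyond the scatter of two such steps

Placing methyl on the saturated chain carbon gave a number 100 percentage points lower from compound 1 to compound 4 (beyond the scatter), and this step also differs from its counterpart among the 3-chlorophenyl compounds: the same change on two cores in this assay, a number 50 percentage points higher (beyond the scatter) from compound 2 to compound 3 and a number 100 percentage points higher (beyond the scatter) from compound 4 to compound 1, 50 percentage points apart, beyond the scatter of two such steps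

These comparisons show that, within these four compounds, the effect of each change depended on the other group, but they rest on a single square of compounds at one dose, and they do not show why the steps differ or how either change would behave on another core; compound 1 and compound 3 also stand at the top of the scale, so the true size of the steps that involve them may not be captured.

The compounds shown leave open whether the same dependence would appear with fluorine or a methoxy group in place of the chlorine, or with an unsubstituted phenyl on the amine nitrogen. They also leave open how a longer chain on the saturated chain carbon would compare with hydrogen and methyl in this assay.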